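Closing the Butylamino Chain into a Seven-Membered Ring

The compounds below may be only part of what the source reports. "The series", "measured", "known", "first", "only" and "open" are said of these compounds alone.

In a functional assay on CHO-K1 cells for antagonist activity at transient receptor potential cation channel subfamily V member 1 (Homo sapiens), read by FLIPR (a higher number here means a weaker inhibitor, a lower number a stronger inhibitor), compound 1 `CCCCNc1nc(C(F)(F)F)ccc1CNC(=O)C(C)c1ccc(NS(C)(=O)=O)c(F)c1` gives 293 nM. Among the three measured compounds it stands second highest: compound 2 `CC(C(=O)NCc1ccc(C(F)(F)F)nc1Nc1ccccc1)c1ccc(NS(C)(=O)=O)c(F)c1` gives 1400 nM, while compound 3 `CCCN(CCC)c1nc(C(F)(F)F)ccc1CNC(=O)C(C)c1ccc(NS(C)(=O)=O)c(F)c1` gives 14.7 nM. Putting phenyl in place of butyl on the ring nitrogen substituent gave a 4.8-fold higher number from compound 1 to compound 2 (0.68 log units; beyond the scatter). Putting dipropylamino in place of butylamino gave a 20-fold lower number from compound 1 to compound 3 (1.30 log units; beyond the scatter), and the same dipropylamino group in place of anilino gave a 95-fold lower number from compound 2 to compound 3 (1.98 log units; beyond the scatter).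

Compound 4 `CC(C(=O)NCc1ccc(C(F)(F)F)nc1N1CCCCCC1)c1ccc(NS(C)(=O)=O)c(F)c1` has not yet been measured. It differs from compound 1 in one place: azepan-1-yl in place of butylamino on an aromatic carbon. Because a 20-fold lower number from compound 1 to compound 3 (1.30 log units; beyond the scatter) came from the closely related exchange of butylamino for dipropylamino, a step of similar size and direction is expected here, namely a 12-fold lower number from compound 1 to compound 4 (1.07 log units; beyond the scatter). Compound 4 is therefore estimated at 25 nM, with a range from 8 nM to 80 nM.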

Compound 4, half-maximal inhibitory concentration: 25.1 nM
For compound 4 the middle estimate is 1.0-fold (0.00 log units) below the measured one; the measured number falls inside the stated range.
By their numbers in this assay, from the lowest: compounds 3 and 4 (each within the scatter of the next); then compound 1; then compound 2.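

Compound 4 shows that this position accepts a ring as well as an open chain: the step to azepan-1-yl from dipropylamino, a 1.7-fold higher number from compound 3 to compound 4 (0.23 log units; within the scatter), leaves the two groups indistinguishable in this assay. The large steps, a 12-fold lower number from compound 1 to compound 4 (1.07 log units; beyond the scatter) and a 56-fold lower number from compound 2 to compound 4 (1.75 log units; beyond the scatter), show that a second group with 0 hydrogen-bond donors, here a seven-membered ring, lies far from both butylamino and anilino, which compound 3 alone could not show. No measurement on hand explains these differences.

The compounds shown leave open how far ring size matters, which a piperidine or pyrrolidine ring at this position would test. They also leave open whether the ring must be all carbon apart from its nitrogen, a question for a morpholine ring, which carries an oxygen.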